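Series notes: five-membered heteroaryl swap at the aromatic carbon

The compounds below may be only part of what the source reports. "The series", "measured", "known", "first", "only" and "open" are said of these compounds alone.

Compound 3 `Cn1cc(-c2ccccc2NCC2=NCCN2)cn1` is one of three measured members of the series. In an in vitro functional assay on cells (Fibroblast) for agonist activity at Alpha-1B adrenergic receptor (Homo sapiens) (on this read-out lower numbers stand for an effect already at smaller amounts and higher numbers for an effect only at larger amounts of compound), compound 3 gives only a limit, < 100000 nM. Compound 1 `Cn1nccc1-c1ccccc1NCC1=NCCN1` likewise gives only a limit in this assay, < 100000 nM. Within the data shown here, compound 2 `c1ccc(-c2nc[nH]n2)c(NCC2=NCCN2)c1` is the one member with a number: in this assay compound 2 gives 5.01 nM. The measured steps that touch compound 3 are a step that the two limits leave unreadable from compound 1 to compound 3 and a step that the limit leaves unreadable from compound 2 to compound 3; the third, a step that the limit leaves unreadable from compound 1 to compound 2, is unreadable as well, since (the limit of < 100000 nM in this assay, at which 2 of the 3 values shown sit).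

Compound 4 `Cn1cccc1-c1ccccc1NCC1=NCCN1` has not yet been measured. The change from compound 3 is 1-methyl-1H-pyrrol-2-yl in place of 1-methyl-1H-pyrazol-4-yl on an aromatic carbon. Among the measured compounds shown here, no measured step reads out a size or direction for this exchange, so there is no basis to expect a step beyond the scatter, nor to rule one out. The working expectation is that a step that the limit leaves unreadable from compound 3 to compound 4 is the step, stated as an estimate only. Compound 4 is therefore estimated at 20000 nM in this assay, with an expected range from 1000 nM to 100000 nM.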

Compound 4, half-maximal effective concentration: < 100000 nM
Compound 4 was reported as a limit (the forecaster's own chance of this, stated with the estimate: 60%); the middle value does not contradict the limit.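

No new step can be read for compound 4 against compound 1, compound 2 or compound 3, since each comparison ends at a limit: the limit of < 100000 nM in this assay, at which 3 of the 4 values shown sit.

The compounds shown leave open whether the 1-methyl-1H-pyrrol-2-yl and 1-methyl-1H-pyrazol-4-yl groups differ at all on this read-out.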